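Replacing pyridin-3-yl with allyl in a cytotoxicity test

This account rests on a few compounds, and the source may have more. Where it says the series, first, only, none or still open, it means among the compounds named here.

Compound 1 `O=C1Nc2ccccc2/C1=N/NC(=S)Nc1ccc2c(c1)CCC2` gives 5800 nM as a measured number
Compound 2 `O=C1Nc2ccccc2/C1=N/NC(=S)Nc1cccnc1` gives > 50000 nM as a limit

Both results come from a functional assay on KB 3-1 cells (Homo sapiens) for cytotoxicity, read by MTT assay, with a stated time of 72 h (on this read-out lower numbers stand for stronger inhibition and higher numbers for weaker inhibition), in this small set. Compound 2 stands at the limit > 50000 nM and so has no exact number.

For the measured compounds named here, the next molecule, compound 3 `C=CCNC(=S)N/N=C1\C(=O)Nc2ccccc21`, keeps the shared core and carries allyl in place of pyridin-3-yl on an amide-type nitrogen as its one change. Going by the values given here, no two measured compounds here differ in a single place, so no earlier step can serve as a guide. Among the compounds with values here, the only clue is that compound 1 reaches a measured 5800 nM in this assay with a different group in that place, which shows that this core can give a real number.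

A modest move toward a lower number, meaning stronger inhibition, is therefore expected, and the estimated change is an at least 2.5-fold lower number from compound 2 to compound 3 (0.39 log units; beyond the scatter) in this reading. In this assay the estimated value for compound 3 is 20000 nM with an expected range from 7000 nM to 50000 nM as the likely span.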

Compound 3, half-maximal inhibitory concentration: 26100 nM
Compound 3: middle estimate off by 1.3-fold (0.12 log units), on the low side; the measured number falls inside the stated range.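

In this assay, putting allyl in place of pyridin-3-yl on the amide-type nitrogen gives an at least 1.9-fold lower number from compound 2 to compound 3 (0.28 log units; that floor lies within the scatter), so this floor alone does not establish a real gain. Compound 2 has only a limit, > 50000 nM, and not an exact number. Compound 3 shows that a measured number at this place does not need a ring, since allyl has none, but the step can be read only as a floor because one end of it is a limit: the limit of > 50000 nM in this assay, at which 1 of the 3 values shown sits.

These compounds cannot tell whether the change from pyridin-3-yl to allyl matters through the loss of the ring, the loss of its nitrogen or the smaller size of the group, since all of these change together in this one step. A plain phenyl group at this nitrogen would separate the ring from its nitrogen, while a longer chain, perhaps ending in an amine or a carboxylic acid, would show how the number in this assay follows the chain beyond allyl.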